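Fluoro in Place of Bromo on Compound 3

This account rests on a few compounds, and the source may have more. Where it says the series, first, only, none or still open, it means among the compounds named here.

In a functional assay on BGC-823 cells (Homo sapiens) for inhibition, read by CCK-8 assay, with a stated time of 48 h (a higher number here means a weaker inhibitor, a lower number a stronger inhibitor), compound 3 `O=C1CSC(N2N=C(c3ccc(Br)cc3)CC2c2ccc3ccccc3c2)=N1` gives 11700 nM, the lowest of the three numbers shown, though all three lie within the scatter of one another: compound 1 `Brc1ccc(C2=NN(C3=NC(c4ccccc4)CS3)C(c3ccc4ccccc4c3)C2)cc1` gives 13000 nM and compound 2 `O=C1CSC(N2N=C(c3ccc(Br)cc3)CC2c2cccc3ccccc23)=N1` gives 14600 nM. Among the measured compounds shown here, the only measured step between compounds that differ in a single place, a 1.1-fold lower number from compound 1 to compound 3 (0.05 log units; within the scatter), is itself within the scatter. Compound 4 `O=C1CSC(N2N=C(c3ccc(F)cc3)CC2c2ccc3ccccc3c2)=N1` differs from compound 3 by fluoro in place of bromo on an aromatic carbon. For the measured compounds named here, no measured step exchanges one halogen for another, so none of the three compounds bears directly on this change. Compound 4 is therefore expected to show a step of a 1.1-fold higher number from compound 3 to compound 4 (0.03 log units; within the scatter), nothing beyond the scatter. The estimate for compound 4 is 12500 nM, within 6000 nM to 26000 nM.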

Compound 4, half-maximal inhibitory concentration: 14900 nM
Estimate against measurement, compound 4: 1.2-fold (0.08 log units) below; the measured number falls inside the stated range.
By their numbers in this assay, from the lowest: compounds 3, 1, 2 and 4 (each within the scatter of the next).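

Among the compounds shown here, the exchange of 4-bromophenyl for 4-fluorophenyl is the first halogen exchange to be read in this assay, and it stays within the scatter (a 1.3-fold higher number from compound 3 to compound 4 (0.11 log units; within the scatter)). At this place, para to a large group, the two halogens therefore cannot be told apart in this assay. No available evidence explains this result. On these data alone, it remains open whether an amine or a carboxylic acid on this aromatic carbon would move the number beyond the scatter. As far as these compounds go, whether the same exchange would read alike on the core of compound 2 also remains open.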